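Second Methyl on an Already Weak Aryl Ether

A few compounds are considered here, and "the series" means these few. Any claim that something is new, unique, unknown or untested is made for them only; others in the source may bear on it.

Three measured compounds share one core and differ only in what sits on the six-membered aromatic ring of carbon only that hangs from it. In an assay on HEK293-TREx cells for antagonist activity at transient receptor potential cation channel subfamily A member 1 (Homo sapiens), read by fluorescence and calcium flux, with a stated time of 72 h (a lower number here means a stronger inhibitor, a higher number a weaker inhibitor), compound 1 `Fc1ccc(Oc2ncnc3[nH]ccc23)c(F)c1` gives 710 nM. Compound 2 `c1ccc(Oc2ncnc3[nH]ccc23)cc1`, which carries no substituent on that ring, gives 3200 nM in this assay. Compound 3 `Cc1ccccc1Oc1ncnc2[nH]ccc12` carries a single methyl on that ring, and in this assay it gives only > 32000 nM, which is a limit of the assay rather than a number. That limit is the limit of > 32000 nM in this assay, at which 1 of the 3 values shown sits. So compound 3 stands at the weak end of what this assay can report, and how far beyond it lies is not known.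

Compound 4 `Cc1ccc(Oc2ncnc3[nH]ccc23)c(C)c1` differs from compound 3 by methyl in place of hydrogen on an aromatic carbon. Among the measured compounds shown here, the one measured step of the same kind is an at least 10-fold higher number from compound 2 to compound 3 (1.00 log units; beyond the scatter), and it points downward in potency. A second methyl on the same ring is therefore expected to move compound 4 further in the same direction or at best hold it at the limit, with a step that the limit leaves unreadable from compound 3 to compound 4 as the estimated step. Compound 4 is expected to give about 60000 nM in this assay, within a range from 20000 nM to 200000 nM, most likely reported again only as a limit.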

Compound 4, half-maximal inhibitory concentration: > 32000 nM
Compound 4: no number, only a limit; the forecaster's own chance of this, stated with the estimate: 85%; the middle value is on the limit's open side.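

No step can be read from compound 3 to compound 4, because each gives only a limit in this assay and not a number: the limit of > 32000 nM in this assay, at which 2 of the 4 values shown sit.

The compounds shown leave open how weak compound 3 and compound 4 truly are, and whether the added methyl changes potency at all.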